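Swapping an Acetyl for a Methylsulfonyl on Compound 1

This account rests on a few compounds, and the source may have more. Where it says the series, first, only, none or still open, it means among the compounds named here.

The compounds here share one core; compound 1 is `CC(=O)Nc1c(-c2ccccc2)oc2ccccc2c1=O`. In a functional assay on KB cells (Homo sapiens) for cytotoxicity (on this read-out higher numbers stand for an effect only at larger amounts of compound and lower numbers for an effect already at smaller amounts), compound 1 gives only a limit, > 100 ug/mL, not a number. Two relatives that carry no acetamido group were measured in the same way: compound 2 is `COc1ccc(-c2cc(=O)c3ccccc3o2)c(OC)c1OC`, and in this assay compound 2 gives 13 ug/mL; compound 3 is `COc1ccccc1-c1cc(=O)c2ccc(OC)c(OC)c2o1`, and in this assay compound 3 gives 4 ug/mL. No pair among these three differs in a single place, so no measured step can be read from them, and compound 1 simply sits at the limit of > 100 ug/mL in this assay, at which 1 of the 3 values shown sits.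

The next compound, compound 4, is `CS(=O)(=O)Nc1c(-c2ccccc2)oc2ccccc2c1=O`. Its difference from compound 1 is methylsulfonyl in place of acetyl on a nitrogen on an aromatic ring. Going by the values given here, with no measured step to lean on, the expectation for compound 4 rests on compound 1 alone, whose result in this assay is a limit rather than a value. The expected step is a number no higher from compound 1 to compound 4 (the limit leaves the size open), a step of no size beyond the usual scatter. Compound 4 is therefore estimated at 100 ug/mL, with a range from 30 ug/mL to 300 ug/mL, and a good chance that the assay again reports only a limit.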

Compound 4, concentration for half-maximal effect: 10 ug/mL
Estimate against measurement, compound 4: 10-fold (1.00 log units) above, and the stated range ends above it.
By their numbers in this assay, from the lowest: compound 3; then compounds 4 and 2 (each within the scatter of the next). At a limit, above all of these: compound 1.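

Going by these compounds alone, on the nitrogen on an aromatic ring, the attached group clearly matters: methylsulfonyl in place of acetyl gives an at least 10-fold lower number from compound 1 to compound 4 (1.00 log units; beyond the scatter) in this assay, the first step in this set that can be read between two compounds differing in one place. Compound 1 gives > 100 ug/mL, which is a limit of the assay and not a number. The printed size of the step is therefore a floor rather than a measured gap, and the real change could be larger, because one end of the step has no exact value: the limit of > 100 ug/mL in this assay, at which 1 of the 4 values shown sits.

A single change at a single place cannot show why the number falls, or whether it is the sulfur, the extra oxygen or something else about the new group that counts. On these data alone, it also remains open what a free amine, a longer chain such as ethylsulfonyl, or a benzenesulfonyl group would give on this same nitrogen, and whether the same swap would lower the number on a core that also carries methoxy groups.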